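A few compounds are considered here, and "the series" means these few. Any claim that something is new, unique, unknown or untested is made for them only; others in the source may bear on it.

Three compounds sharing one core have been examined in an assay on cells for agonist activity at vitamin D3 receptor (Homo sapiens), with a stated time of 96 h; on this read-out higher numbers stand for an effect only at larger amounts of compound and lower numbers for an effect already at smaller amounts. Compound 1 `CCn1c(C(=O)N(CCC#N)CCC#N)ccc1C(CC)(CC)c1ccc(OCCC(O)(CC)CC)c(C)c1` returns only a limit in this assay, > 10000 nM. Compound 2 `C=CCN(C)C(=O)c1ccc(C(CC)(CC)c2ccc(OCCC(O)(CC)CC)c(C)c2)n1CC` likewise returns a limit, > 10000 nM. Compound 3 `C#CCCOC(=O)c1ccc(C(CC)(CC)c2ccc(OCCC(O)(CC)CC)c(C)c2)n1CC` is the only one of the three with an actual number in this assay, 6030 nM. The steps of an at least 1.6-fold lower number from compound 1 to compound 3 (0.21 log units; that floor lies within the scatter) and an at least 1.6-fold lower number from compound 2 to compound 3 (0.21 log units; that floor lies within the scatter) both rest on the limit (the limit of > 10000 nM in this assay, at which 2 of the 3 values shown sit), so their true size is not known, and a step that the two limits leave unreadable from compound 1 to compound 2 cannot be read at all.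

Compound 4 `CCOc1ccc(NC(=O)c2ccc(C(CC)(CC)c3ccc(OCCC(O)(CC)CC)c(C)c3)n2CC)cc1` has not yet been measured. It differs from compound 3 in one place: (4-ethoxyphenyl)amino in place of (but-3-yn-1-yl)oxy on a carbonyl carbon. Both measured steps that end at compound 3 replaced an amino group on the carbonyl carbon with the (but-3-yn-1-yl)oxy group; compound 4 puts an amino group back on that carbonyl carbon, though one bearing a six-membered aromatic ring, which neither compound 1 nor compound 2 carries. A rise in the number is therefore expected, a 1.5-fold higher number from compound 3 to compound 4 (0.17 log units; within the scatter), with a fair chance that this assay again reports only a limit. The estimate for compound 4 is 9000 nM, between 2000 nM and 40000 nM.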

Compound 4, half-maximal effective concentration: 1630 nM
For compound 4 the middle estimate is 5.5-fold (0.74 log units) above the measured one, outside the stated range (below it).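

In this assay, the change to (4-ethoxyphenyl)amino on the carbonyl carbon gives a 3.7-fold lower number from compound 3 to compound 4 (0.57 log units; beyond the scatter), and this is the only step among the compounds shown that rests on two actual numbers and lies beyond the scatter. An amino group at this place is therefore compatible with a measured number, and compound 4, which carries one, stands lower than compound 3, which carries (but-3-yn-1-yl)oxy instead. The comparisons with the other two amino groups point the same way, with an at least 6.1-fold lower number from compound 2 to compound 4 (0.78 log units; beyond the scatter) and an at least 6.1-fold lower number from compound 1 to compound 4 (0.78 log units; beyond the scatter), but these two steps give only a floor and their true size is not known: the limit of > 10000 nM in this assay, at which 2 of the 4 values shown sit.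

The compounds shown leave open which part of (4-ethoxyphenyl)amino goes with the lower number, as the six-membered aromatic ring, the ethoxy group and the amide hydrogen all enter together in this one change. A plain phenylamino group or a 4-methoxyphenylamino group on the same carbonyl carbon would begin to separate these parts, and a carboxylic acid there remains an open comparison with both the ester and the amides.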